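Amine chain variation on the amide of the shared core

The compounds below may be only part of what the source reports. "The series", "measured", "known", "first", "only" and "open" are said of these compounds alone.

Measured so far in a functional assay on cells (Pituitary gland cell) with growth hormone secretagogue receptor type 1 (Rattus norvegicus) as the target; a lower number here means that less compound is needed, a higher number that more compound is needed for the effect:
compound 1 `CC(C)(CC(=O)N[C@@H]1CCc2ccccc2N(Cc2ccc(-c3ccccc3-c3nn[nH]n3)cc2)C1=O)NCc1ccccc1` gives 65 uM
compound 2 `CC(C)(N)C(=O)N[C@@H]1CCc2ccccc2N(Cc2ccc(-c3ccccc3-c3nn[nH]n3)cc2)C1=O` gives 0.03 uM
compound 3 `CC(C)(CN)C(=O)N[C@@H]1CCc2ccccc2N(Cc2ccc(-c3ccccc3-c3nn[nH]n3)cc2)C1=O` gives 3 uM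

Compound 3 holds the second highest of the three numbers: compound 2 sits far lower, the step being a 100-fold higher number from compound 2 to compound 3 (2.00 log units; beyond the scatter), while compound 1 sits higher, the step being a 22-fold lower number from compound 1 to compound 3 (1.34 log units; beyond the scatter). Compound 4 `CCCNC(C)(C)CC(=O)N[C@@H]1CCc2ccccc2N(Cc2ccc(-c3ccccc3-c3nn[nH]n3)cc2)C1=O` is not yet measured; the change from compound 3 is 2-methyl-2-(propylamino)propyl in place of 1-(aminomethyl)-1-methylethyl on a carbonyl carbon. This brings back the chain type of compound 1, with a propyl group where compound 1 carries a benzyl group. The bearing steps are a 22-fold lower number from compound 1 to compound 3 (1.34 log units; beyond the scatter) and, for the same chain type against the shortest amine, a 2200-fold lower number from compound 1 to compound 2 (3.34 log units; beyond the scatter); both place the longer chain well above the short amines. A step upward from compound 3 is therefore expected, probably landing near compound 1, with width on either side since the benzyl-to-propyl swap itself is unmeasured. Compound 4 is expected at 30 uM (range 5 uM to 150 uM), an estimated step of a 10-fold higher number from compound 3 to compound 4 (1.00 log units; beyond the scatter).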

Compound 4, concentration for half-maximal effect: 50 uM
Compound 4: middle estimate off by 1.7-fold (0.22 log units), on the low side, within the range that was stated.
By their numbers in this assay, from the lowest: compound 2; then compound 3; then compounds 4 and 1 (each within the scatter of the next).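

In this assay the 2-methyl-2-(propylamino)propyl chain sits far above both short amines (a 17-fold higher number from compound 3 to compound 4 (1.22 log units; beyond the scatter)) (a 1700-fold higher number from compound 2 to compound 4 (3.22 log units; beyond the scatter)). Ethyl in place of phenyl on the saturated chain carbon bound to the amine nitrogen gives a step within the scatter (a 1.3-fold lower number from compound 1 to compound 4 (0.11 log units; within the scatter)), so compounds 1 and 4 show no separation between the benzyl and propyl groups on this chain. No measurement shown gives a reason for these steps.

Open, going by these compounds, is whether an unsubstituted amine in place of the propylamino group would bring this longer chain closer to compound 2. Also open, on these data alone, is whether a methyl group on the amine of compound 2 would be tolerated.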